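This account rests on a few compounds, and the source may have more. Where it says the series, first, only, none or still open, it means among the compounds named here.

In a functional assay on MCF7 cells (Homo sapiens) for antiproliferative activity, with a stated time of 72 h (on this read-out lower numbers stand for stronger inhibition and higher numbers for weaker inhibition), compound 2 `CCN(CC)Cc1c(OC)cc(OC)c(C(=O)/C=C/c2ccccc2Cl)c1O` holds the lower of the two numbers at 2700 nM while compound 1 `COc1cc(OC)c(C(=O)/C=C/c2ccccc2Cl)c(O)c1CN(C)CC(=O)O` gives 73200 nM as its value. Compound 3 `COc1cc(OC)c(C(=O)/C=C/c2ccccc2Cl)c(O)c1CN(C)C` has dimethylamino in place of diethylamino on a saturated chain carbon bound to an aromatic carbon. Among the compounds with values here, the only measured step at that place (a 27-fold lower number from compound 1 to compound 2 (1.43 log units; beyond the scatter)) is large, but it starts from (carboxymethyl)(methyl)amino, which compound 3 does not carry, so it fixes no size for this change. In this assay a small rise, or none beyond the scatter, is expected. The expected step is small (a 1.5-fold higher number from compound 2 to compound 3 (0.17 log units; within the scatter)). Compound 3 is estimated at 4000 nM (from 1500 nM to 12000 nM).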

Compound 3, half-maximal inhibitory concentration: 90 nM
The estimate for compound 3 lay 44-fold (1.65 log units) above the measured number; the whole stated range lies above it.
By their numbers in this assay, from the lowest: compound 3; then compound 2; then compound 1.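

In this assay, the amine on a saturated chain carbon bound to an aromatic carbon proves sensitive to small changes: dimethylamino in place of diethylamino alone gives a 30-fold lower number from compound 2 to compound 3 (1.48 log units; beyond the scatter) despite the same counted donors and acceptors and no net charge on either group. Hydrogen in place of carboxy on a saturated chain carbon bound to an amine nitrogen gives an 810-fold lower number from compound 1 to compound 3 (2.91 log units; beyond the scatter) and is the largest step in the series. No evidence on the cause of either step is available.

As far as these compounds go, whether a mixed ethyl(methyl)amino group would fall between compound 2 and compound 3 remains open. So does how a cyclic amine such as pyrrolidine or morpholine, or a primary amine, would compare with dimethylamino.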